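Capping the side-chain hydroxyl of a naphthoquinone as an acetate

This account rests on a few compounds, and the source may have more. Where it says the series, first, only, none or still open, it means among the compounds named here.

Measured compounds:
Compound 1, `CC(C)=CC[C@@H](OC[C@@H](C)O)C1=CC(=O)c2c(O)ccc(O)c2C1=O`: 22500 nM
Compound 2, `CCC(O)(CC)CC(=O)O[C@H](CC=C(C)C)C1=CC(=O)c2c(O)ccc(O)c2C1=O`: 52000 nM

Both compounds share a core and were tested in a functional assay on HeLa cells (Homo sapiens) for cytotoxicity, read by MTT assay; a higher number here means a weaker inhibitor, a lower number a stronger inhibitor. Compound 1 gives 22500 nM, the lowest of the two numbers shown; its only neighbour is compound 2, and the step of a 2.3-fold higher number from compound 1 to compound 2 (0.36 log units; beyond the scatter) puts compound 2 further from the strong end.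

Compound 3, `CC(=O)OC(C)CO[C@H](CC=C(C)C)C1=CC(=O)c2c(O)ccc(O)c2C1=O`, has not yet been measured. It differs from compound 1 in one place: 1-acetoxyethyl in place of 1-hydroxyethyl on a saturated chain carbon bound to an oxygen on a saturated carbon. The free hydroxyl of compound 1 is thus converted to an ester.

Within the data shown here, the only step that bears on this is a 2.3-fold higher number from compound 1 to compound 2 (0.36 log units; beyond the scatter), where turning the hydroxyl-bearing side chain into an ester-bearing one also raised the number by a modest amount. Compound 3 is therefore expected to sit somewhat above compound 1, with a step of a 1.4-fold higher number from compound 1 to compound 3 (0.15 log units; within the scatter) estimated. Compound 3 is estimated at 32000 nM, within 13000 nM to 80000 nM.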

Compound 3, half-maximal inhibitory concentration: 40100 nM
Estimate against measurement, compound 3: 1.3-fold (0.10 log units) below; the range from low to high includes it.
By their numbers in this assay, from the lowest: compounds 1, 3 and 2 (each within the scatter of the next, the first and the last beyond it).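

Read in this assay, 1-acetoxyethyl in place of 1-hydroxyethyl gives a 1.8-fold higher number from compound 1 to compound 3 (0.25 log units; within the scatter), so on this saturated chain carbon, capping the hydroxyl as an ester makes no difference that can be told from repeat measurements. The hydrogen-bond donor counted for 1-hydroxyethyl can therefore be given up here without a readable cost in this read-out. Compound 3 also shows a 1.3-fold lower number from compound 2 to compound 3 (0.11 log units; within the scatter), which leaves it unseparated from either of the other two compounds, even though those two lie apart beyond the scatter.

As far as these compounds go, whether an amine, a carboxylic acid or a longer chain at this place would move the number beyond the scatter remains open. No measurement shown here explains these numbers.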